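From Nitro to Cyano in Compound 3

The source may hold more compounds than are shown below. What is called first, only, known or untested is meant among the compounds shown, and "the series" means these compounds.

In an ADME assay on MT4 cells (Homo sapiens) for cytotoxicity, read by MTT assay, with a stated time of 5 days (on this read-out higher numbers stand for lower toxicity in this test and lower numbers for higher toxicity in this test), compound 2 (`Cc1cc(OCC(=O)Nc2ccc([N+](=O)[O-])cc2)nc(Nc2ccc(C#N)cc2)n1`) gives > 309000 nM as a limit, not a number. In this assay compound 1 (`N#Cc1ccc(NC(=O)COc2ccnc(Nc3ccc(C#N)cc3)n2)cc1`) likewise gives > 337000 nM as a limit. Compound 3 (`Cc1cc(OCC(=O)Nc2ccc(C#N)cc2)nc(Nc2ccc(C#N)cc2)n1`) is still unmeasured: it differs from compound 2 by a single change (cyano in place of nitro on an aromatic carbon) para to a large group. Going by the values given here, no measured step offers a guide, so no change beyond the scatter is expected in this assay and the estimated step that the limit leaves unreadable from compound 2 to compound 3 stays small. Compound 3 is expected at 325000 nM within an estimated range of 160000 nM to 400000 nM and may again appear only as a limit.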

Compound 3, half-maximal cytotoxic concentration: > 325000 nM
Compound 3: a limit, no number; the forecaster's own chance of this, stated with the estimate: 80%; the middle value sits exactly at the limit.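

Going by these compounds alone, compound 1, compound 2 and compound 3 all give limits in this assay, not numbers, so no step between them can be read. The compounds shown leave open whether cyano in place of nitro, or methyl in place of hydrogen, changes cytotoxicity at all.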